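Swapping the biphenyl arm for a small aminophenyl group

A few compounds are considered here, and "the series" means these few. Any claim that something is new, unique, unknown or untested is made for them only; others in the source may bear on it.

Measured compounds:
- compound 1, `NC1CCC(Nc2nc(NCc3ccc(-c4ccccc4)cc3)c3ncn(C4CCCC4)c3n2)CC1`: 745 nM
- compound 2, `NC1CCC(Nc2nc(NCc3ccc(-c4ccccc4O)nc3)c3ncn(C4CCCC4)c3n2)CC1`: 35 nM

Of the compounds shown here, two share a common core and have been tested in a functional assay on HCT-116 cells (Homo sapiens) for inhibition, with a stated time of 72 h; a lower number here means a stronger inhibitor, a higher number a weaker inhibitor. Compound 1 gives 745 nM, the highest number of the two, while compound 2 reaches 35 nM, a gap well beyond the usual scatter. Compound 2 differs from compound 1 in more than one place, so no single step can be read from that pair.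

Compound 3, `Nc1ccccc1CNc1nc(NC2CCC(N)CC2)nc2c1ncn2C1CCCC1`, has not yet been measured. Relative to compound 1 it carries one change: 2-aminophenyl in place of 4-phenylphenyl on a saturated chain carbon bound to a nitrogen on an aromatic ring. Among the compounds with values here, no measured pair shows what such a change does here. A step of modest size, in either direction, seems most plausible, and the expected step from compound 1 to compound 3 is a 1.9-fold lower number from compound 1 to compound 3 (0.27 log units; within the scatter). Compound 3 is therefore estimated at 400 nM, within a range from 80 nM to 2000 nM.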

Compound 3, half-maximal inhibitory concentration: 2300 nM
Beside the measured number, compound 3's estimate is 5.8-fold (0.76 log units) below it, outside the stated range (above it).
By their numbers in this assay, from the lowest: compound 2; then compound 1; then compound 3.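

In this assay, within the data shown here, putting 2-aminophenyl in place of 4-phenylphenyl on a saturated chain carbon bound to a nitrogen on an aromatic ring gives a 3.1-fold higher number from compound 1 to compound 3 (0.49 log units; beyond the scatter), the first single-place step that can be read. It shows that this place is sensitive to the group it carries, and that this smaller group with its amine gives a weaker inhibitor than 4-phenylphenyl. No measurement shown explains the rise.

The swap removes one carbon-only aromatic ring and adds an amine in a single move, so a plain phenyl group at this place would be needed to tell those two parts apart. Steps involving compound 2 cannot be read, since it differs from the others in more than one place.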